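The source may report more compounds than this note shows. Statements on the series, on what has been measured and on what is new or still open speak of the compounds shown alone.

Values in a functional assay on EBC-1 cells (Homo sapiens) for antiproliferative activity, with a stated time of 72 h; on this read-out higher numbers stand for weaker inhibition and lower numbers for stronger inhibition:
- compound 1 `N#Cc1cccc(-c2cc(F)c3ncc(Cc4ccc5ncccc5c4)n3c2)c1`: 107 nM
- compound 2 `N#Cc1ccc(-c2cc(F)c3ncc(Cc4ccc5ncccc5c4)n3c2)cc1F`: 145 nM
- compound 3 `CNC(=O)c1cccc(-c2cc(F)c3ncc(Cc4ccc5ncccc5c4)n3c2)c1`: 400 nM

On these numbers, the second-highest place is not clearly separated from the lowest: a 1.4-fold higher number from compound 1 to compound 2 (0.13 log units; within the scatter). The highest stands clearly apart: a 2.8-fold higher number from compound 2 to compound 3 (0.44 log units; beyond the scatter).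

Compound 4 `O=C(NCC1CCCCN1)c1ccc(-c2cc(F)c3ncc(Cc4ccc5ncccc5c4)n3c2)cc1F` carries ((piperidin-2-yl)methyl)carbamoyl in place of cyano on an aromatic carbon.

The closest measured change is the modest 3.7-fold higher number from compound 1 to compound 3 (0.57 log units; beyond the scatter), which also replaces cyano with an amide. For the measured compounds named here, no measured compound carries the piperidine ring, so the size remains uncertain. A modest rise of similar size is expected in this assay: a 2.8-fold higher number from compound 2 to compound 4 (0.44 log units; beyond the scatter).

The estimate for compound 4 is 400 nM, with an expected range of 120 nM to 1300 nM.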

Compound 4, half-maximal inhibitory concentration: 277 nM
The estimate for compound 4 lay 1.4-fold (0.16 log units) above the measured number, and the stated range covers the measured number.
By their numbers in this assay, from the lowest: compounds 1, 2, 4 and 3 (each within the scatter of the next, the first and the last beyond it).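

In this assay, the aromatic carbon ortho to a fluoro group takes ((piperidin-2-yl)methyl)carbamoyl in place of cyano, with a 1.9-fold higher number from compound 2 to compound 4 (0.28 log units; within the scatter). The earlier compounds shown here carried nothing larger than methylcarbamoyl on their outer phenyl ring, whereas this group brings in a six-membered non-aromatic ring without a step beyond the scatter. Nothing available explains this result. The compounds shown leave open whether the ring nitrogen matters, as a cyclohexyl ring in place of the piperidine would test. As far as these compounds go, how a carboxylic acid or an open-chain amine would read on this carbon also remains open.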